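Replacing methoxy with amino in compound 1

This account rests on a few compounds, and the source may have more. Where it says the series, first, only, none or still open, it means among the compounds named here.

In a functional assay on KBVIN cells (Homo sapiens) for antiproliferative activity, read by sulforhodamine B assay, with a stated time of 48 h (on this read-out lower numbers stand for stronger inhibition of growth and higher numbers for weaker inhibition of growth), compound 1 `COc1ccc(Nc2nc(NCCCO)c3ccccc3n2)cc1` gives 17100 nM as the second highest of three numbers, while compound 2 `CCCNc1nc(Nc2ccc(OC)cc2)nc2ccccc12` gives 5090 nM and compound 3 `COc1ccc(N(C)c2nc(NCCCO)c3ccccc3n2)cc1` gives 30800 nM on the same read-out. Compound 4 `Nc1ccc(Nc2nc(NCCCO)c3ccccc3n2)cc1` differs from compound 1 by amino in place of methoxy on an aromatic carbon in one place: amino in place of methoxy on an aromatic carbon, para to a large group. Neither measured step touches that carbon. The change on the chain gave a 3.4-fold lower number from compound 1 to compound 2 (0.53 log units; beyond the scatter) and the added methyl on nitrogen gave a 1.8-fold higher number from compound 1 to compound 3 (0.26 log units; within the scatter) in this assay so neither is a direct guide. No step beyond the scatter is therefore expected, and the estimated step is a 1.1-fold lower number from compound 1 to compound 4 (0.06 log units; within the scatter) on this evidence. For compound 4 the expected value is 15000 nM with an estimated range from 5000 nM to 40000 nM around it.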

Compound 4, concentration for 50% growth inhibition: 18700 nM
Compound 4: middle estimate off by 1.2-fold (0.10 log units), on the low side; measured number inside the range.
By their numbers in this assay, from the lowest: compound 2; then compounds 1, 4 and 3 (each within the scatter of the next).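

In this assay the first change made on this aromatic carbon, para to a large group, gives a 1.1-fold higher number from compound 1 to compound 4 (0.04 log units; within the scatter) and so stays within the scatter. For this pair, the 4-methoxyphenyl and 4-aminophenyl forms cannot be told apart on this read-out. Nothing measured here accounts for that likeness. Going by these compounds, it remains open whether a hydroxy group, a carboxylic acid or a dimethylamino group on this carbon would also read alike. Equally open, on these data alone, is whether amino in place of methoxy would behave the same way on the chain of compound 2.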